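Swapping the amine on the shared core: exposure outlook

This account rests on a few compounds, and the source may have more. Where it says the series, first, only, none or still open, it means among the compounds named here.

Compound 1 `Cc1cn2c(-c3cn[nH]c3)cnc2c(Nc2cc(CN3CCCCC3(C)C)ns2)n1` has been run through an ADME assay on the whole organism (plasma) for pharmacokinetics, with Rattus norvegicus as the target, with a stated time of 6 h, at a dose of 10 mg/kg by the oral route (on this read-out lower numbers stand for lower exposure and higher numbers for higher exposure at the dose given), and on that read-out compound 1 gives 211 ng.h/mL. Compound 2 `Cc1cn2c(-c3cn[nH]c3)cnc2c(Nc2cc(CN3CCN(C)CC3)ns2)n1` carries the same shared core but a 4-methylpiperazin-1-yl group in place of the amine of compound 1; for compound 2 the outcome in this assay is "not determined" (no result reported), so no number stands for it and its position cannot be placed against compound 1. Compound 3 `Cc1cn2c(-c3cn[nH]c3)cnc2c(Nc2cc(CN3C[C@H]4CC[C@@H](C3)O4)ns2)n1` is the next variation, differing from compound 2 only at one spot (a group of 8 heavy atoms (6 carbon, 1 nitrogen, 1 oxygen; one five-membered non-aromatic ring with 1 hetero atom, one six-membered non-aromatic ring with 2 hetero atoms) in place of a group of 7 heavy atoms (5 carbon, 2 nitrogen; one six-membered non-aromatic ring with 2 hetero atoms), on a saturated chain carbon bound to an aromatic carbon).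

Since compound 2 has no measured value, the step from compound 2 to compound 3 cannot be sized from data. Among the measured compounds shown here, the only anchor is compound 1, which shares the core and the same attachment point for its amine. The change from compound 2 to compound 3 is a small one in atom count, so any step would be expected to fall within the usual scatter rather than beyond it, in no clear direction.

Compound 3 is expected to reach about 200 ng.h/mL in this assay, with a plausible range from 50 ng.h/mL to 800 ng.h/mL.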

Compound 3, area under the concentration-time curve: 169 ng.h/mL
For compound 3 the middle estimate is 1.2-fold (0.07 log units) above the measured one; low and high end bracket the measured number.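

In this assay, among the compounds shown here, the new result gives the first step that can be read at this position, on a saturated chain carbon bound to an aromatic carbon: a 1.2-fold lower number from compound 1 to compound 3 (0.10 log units; within the scatter). The single-ring amine of compound 1 and the oxygen-containing two-ring group of compound 3 therefore cannot be told apart on this read-out, even though the two groups differ in ring structure and one carbon is exchanged for an oxygen, so at least this one exchange leaves oral exposure in the rat within the normal spread of repeat measurements. No accompanying measurement is available that would explain this outcome.

Going by these compounds, the step involving compound 2 cannot be read, as compound 2 has no number, so how the 4-methylpiperazin-1-yl group compares with the other two amines remains unknown. On these data alone, two compounds cannot show how far this tolerance extends, and it remains open whether a plain morpholine or a small open-chain amine such as dimethylamine, placed on the same chain carbon, would also stay within the scatter of compound 3.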